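This account rests on a few compounds, and the source may have more. Where it says the series, first, only, none or still open, it means among the compounds named here.

Measured in a functional assay on MCF7 cells (Homo sapiens) for antiproliferative activity, read by CCK-8 assay, with a stated time of 48 h; a higher number here means a weaker inhibitor, a lower number a stronger inhibitor:

compound 1, `COc1ccc2[nH]c(C)c(C3=C(Br)C(=O)C(c4c(-c5ccccc5)[nH]c5ccccc45)=C(Br)C3=O)c2c1`: 2.57 ug/mL
compound 2, `Cc1[nH]c2ccccc2c1C1=C(Br)C(=O)C(c2c(-c3ccccc3)[nH]c3ccccc23)=C(Br)C1=O`: 3.02 ug/mL
compound 3, `COc1ccc2[nH]c(C)c(C3=C(Cl)C(=O)C(c4c(-c5ccc(C)cc5)[nH]c5ccccc45)=C(Cl)C3=O)c2c1`: 3.11 ug/mL

Among the compounds with values here, the one counted step in the set is hydrogen in place of methoxy on an aromatic carbon. Its effect is a 1.2-fold higher number from compound 1 to compound 2 (0.07 log units; within the scatter), so removing the methoxy left the read-out essentially where it was. Compound 3 carries the methoxy as compound 1 does, but the two differ in more than one place, and the difference between the two cores is not broken down here; what can be said is that compound 1 and compound 3 give values within the scatter of each other, as do compound 2 and compound 3.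

Compound 4, `Cc1ccc(-c2[nH]c3ccccc3c2C2=C(Cl)C(=O)C(c3c(C)[nH]c4ccccc34)=C(Cl)C2=O)cc1`, is not yet measured. It stands to compound 3 as compound 2 stands to compound 1: the difference is hydrogen in place of methoxy on an aromatic carbon, and the place description is the same word for word as for the earlier pair, so this is the same change on a second core.

Within the data shown here, with only one prior instance, the expectation rests on that instance alone: the step from compound 1 to compound 2 was within the scatter, and the step from compound 3 to compound 4 is expected to be of similar size, a 1.1-fold higher number from compound 3 to compound 4 (0.05 log units; within the scatter), because compound 1 to compound 2 gave a 1.2-fold higher number from compound 1 to compound 2 (0.07 log units; within the scatter). Whether a core that differs in several places transmits the change identically is not tested here, so the range is kept wide. For compound 4 the expected value in this assay is 3.5 ug/mL, with a range from 1.8 ug/mL to 7 ug/mL.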

Compound 4, half-maximal inhibitory concentration: 2.8 ug/mL
Beside the measured number, compound 4's estimate is 1.3-fold (0.10 log units) above it; low and high end bracket the measured number.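

In this assay, taking the methoxy off the second core gives a 1.1-fold lower number from compound 3 to compound 4 (0.05 log units; within the scatter), so the change from 5-methoxy-2-methyl-1H-indol-3-yl to 2-methyl-1H-indol-3-yl leaves the read-out where it stood, as it did on the core of compound 1. Set side by side, the two steps show no difference that can be told apart, and the change carries from one core to the other in this series: the same change on two cores in this assay, a 1.2-fold higher number (0.07 log units; within the scatter) from compound 1 to compound 2 and a 1.1-fold lower number (0.05 log units; within the scatter) from compound 3 to compound 4, 1.3-fold (0.12 log units) apart, within the scatter of two such steps This shows only that the loss of the methoxy makes no measurable difference on these two cores in this one assay; the opposite directions of the two steps carry no meaning at this size, and nothing here says how the change would behave on any other core or in any other read-out.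

The compounds shown hold only methoxy or hydrogen at this place on the ring, so whether an amine, a carboxylic acid or a longer chain there would move the read-out remains open. The two cores also differ in more than one place, so the separate contributions of the bromine and chlorine atoms and of the extra methyl on the phenyl cannot be read.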